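Compound 3 to compound 4: a larger group on the chain

The compounds below may be only part of what the source reports. "The series", "measured", "known", "first", "only" and "open" are said of these compounds alone.

compound 1 `C=CCOc1cc(/C=C\c2cc(OC)c(OC)c(OC)c2)ccc1OC`: 43500 nM
compound 2 `C/C=C/COc1cc(/C=C\c2cc(OC)c(OC)c(OC)c2)ccc1OC`: 135000 nM
compound 3 `COc1ccc(/C=C\c2cc(OC)c(OC)c(OC)c2)cc1OCc1ccc(Br)cc1`: 45000 nM

In an ADME assay on HEK293 cells (Homo sapiens) for inhibition, read by MTT assay, with a stated time of 3 days (a higher number here means a weaker inhibitor, a lower number a stronger inhibitor), compound 3 gives 45000 nM, which places it level with compound 1 and well apart from compound 2. Against the first there is a 1.0-fold higher number from compound 1 to compound 3 (0.01 log units; within the scatter). Against the second there is a 3.0-fold lower number from compound 2 to compound 3 (0.48 log units; beyond the scatter).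

The next structure, compound 4 `COc1cccc(/C=C/CCCOc2cc(/C=C\c3cc(OC)c(OC)c(OC)c3)ccc2OC)c1`, has not yet been measured. It keeps the shared core, but 4-(3-methoxyphenyl)but-3-en-1-yl stands in place of 4-bromophenyl on a saturated chain carbon bound to an oxygen on an aromatic ring: 4-(3-methoxyphenyl)but-3-en-1-yl in place of 4-bromophenyl on a saturated chain carbon bound to an oxygen on an aromatic ring.

Going by the values given here, all the measured steps were made at this same place. Besides the two above, there is a 3.1-fold higher number from compound 1 to compound 2 (0.49 log units; beyond the scatter). Across these three compounds, the steps are modest or lie within the scatter. None of the three measured compounds carries the entering group, however, so these steps give only a rough scale and no firm direction. Nothing in them points to a large move in this assay, and no step beyond the scatter is expected. The expected step is a 1.3-fold higher number from compound 3 to compound 4 (0.12 log units; within the scatter). For compound 4 the estimated value is 60000 nM, with an expected range from 25000 nM to 150000 nM.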

Compound 4, half-maximal inhibitory concentration: 39000 nM
Beside the measured number, compound 4's estimate is 1.5-fold (0.19 log units) above it; the measured number falls inside the stated range.
By their numbers in this assay, from the lowest: compounds 4, 1 and 3 (each within the scatter of the next); then compound 2.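

Replacing 4-bromophenyl with the larger 4-(3-methoxyphenyl)but-3-en-1-yl on a saturated chain carbon bound to an oxygen on an aromatic ring gives, in this assay, a 1.2-fold lower number from compound 3 to compound 4 (0.06 log units; within the scatter) and leaves the reading level with that of the vinyl-ended compound, as a 1.1-fold lower number from compound 1 to compound 4 (0.05 log units; within the scatter) shows. Going by these compounds alone, the position therefore accepts a group of 12 heavy atoms, with a double bond outside the aromatic ring and a hydrogen-bond acceptor, without a step beyond the scatter, something the earlier compounds, none of which carried so long a group, could not show. Compound 2, with its prop-1-en-1-yl group, remains the one apart from the other three, as a 3.5-fold lower number from compound 2 to compound 4 (0.54 log units; beyond the scatter) confirms, so size does not order these four compounds, and nothing available accounts for this.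

The compounds shown leave open whether an amine or a carboxylic acid on this chain would move the number beyond the scatter. They also leave open whether 4-(3-methoxyphenyl)butyl, the same chain with its double bond saturated, would read level with compound 4.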